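The source may hold more compounds than are shown below. What is called first, only, known or untested is meant among the compounds shown, and "the series" means these compounds.

The series shares the core of compound 1 `C#CC(=O)Nc1ccc2c(c1)/C(=C/c1ccc[nH]1)C(=O)N2` and varies the aryl group on the double bond and the acyl group on the amide. In a functional assay on CCRF-CEM cells (Homo sapiens) for antiproliferative activity, read by MTT assay, with a stated time of 72 h (a higher number here means a weaker inhibitor, a lower number a stronger inhibitor), compound 1 gives 50 nM. For the measured compounds named here, compound 2 `C=C(Br)C(=O)Nc1ccc2c(c1)/C(=C\c1ccsc1)C(=O)N2` gives 96 nM in this assay, the highest of the three numbers so far; compound 1 sits within the scatter of it. Going by the values given here, compound 3 `C=C(Br)C(=O)Nc1ccc2c(c1)/C(=C/c1ccsc1)C(=O)N2` gives 4 nM in this assay, the lowest of the three; the step of a 24-fold lower number from compound 2 to compound 3 (1.38 log units; beyond the scatter) is large, and the only thing the two compounds do not share is the configuration as drawn (the fact that compounds 2 and 3 differ only in the configuration as drawn).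

Compound 4 `C=C(Br)C(=O)Nc1ccc2c(c1)/C(=C\c1ccc(C)s1)C(=O)N2` is not yet measured in this assay. It differs from compound 2 in one place: 5-methylthiophen-2-yl in place of thiophen-3-yl on a double-bonded chain carbon bound to a double-bonded ring carbon. Among the compounds with values here, no measured step exchanges the aryl group alone; the single step known, a 24-fold lower number from compound 2 to compound 3 (1.38 log units; beyond the scatter), concerns configuration and not the ring, so it gives no direct guide to the size of an aryl exchange. Compound 2 and compound 4 share the configuration as drawn. Within the data shown here, with no step of this kind on record, the expectation for compound 4 is a number near that of compound 2, the step of a 1.2-fold lower number from compound 2 to compound 4 (0.08 log units; within the scatter) expected to stay within the scatter. The estimate for compound 4 in this assay is 80 nM, expected between 25 nM and 250 nM.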

Compound 4, half-maximal inhibitory concentration: 1 nM
Compound 4: the middle estimate sits 80-fold (1.90 log units) above what was measured, and the stated range ends above it.
By their numbers in this assay, from the lowest: compound 4; then compound 3; then compounds 1 and 2 (each within the scatter of the next).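

With the configuration as drawn held fixed, the aryl group on a double-bonded chain carbon bound to a double-bonded ring carbon proves a strong lever in this assay: 5-methylthiophen-2-yl in place of thiophen-3-yl gives a 96-fold lower number from compound 2 to compound 4 (1.98 log units; beyond the scatter). For the compounds shown here, this position therefore responds to the ring exchange alone, whereas the one earlier large step, a 24-fold lower number from compound 2 to compound 3 (1.38 log units; beyond the scatter), concerned configuration and showed nothing about the aryl group: the fact that compounds 2 and 3 differ only in the configuration as drawn. No measurement shown speaks to what lies behind the new step.

The exchange joins two changes in one step, the point of attachment of the thiophene and the added methyl, and an unsubstituted thiophen-2-yl would be needed to divide the step between them. Also open, from the compounds shown here alone, are whether an ethyl group, an aminomethyl group or a carboxylic acid in place of the methyl would keep the number this low in this assay and whether the opposite double-bond configuration of the 5-methylthiophen-2-yl compound would shift the number as configuration did for the thiophen-3-yl pair.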